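From Pyrimidin-2-yl to Pyridazin-3-yl on the Triple-Bonded Carbon

The compounds below may be only part of what the source reports. "The series", "measured", "known", "first", "only" and "open" are said of these compounds alone.

In an assay on CHO cells for displacement of a labelled ligand from adenosine receptor A1 (Homo sapiens), read by scintillation counting, with a stated time of 60 min, tested at 10 uM (a higher number here means more inhibition at the concentration tested (going by the name of the read-out), a lower number less inhibition), compound 3 `CNC(=O)[C@@]12C[C@@H]1[C@@H](n1cnc3c(NC)nc(C#Cc4ncccn4)nc31)[C@H](O)[C@@H]2O` gives 25%, the largest of the three numbers, though each of the others lies within the scatter of it: compound 2 `CNC(=O)[C@@]12C[C@@H]1[C@@H](n1cnc3c(NC)nc(C#Cc4ccccc4F)nc31)[C@H](O)[C@@H]2O` gives 20% and compound 1 `CNC(=O)[C@@]12C[C@@H]1[C@@H](n1cnc3c(NC)nc(C#Cc4ccccc4)nc31)[C@H](O)[C@@H]2O` gives 18%. The steps of a number 7 percentage points higher from compound 1 to compound 3 (within the scatter) and a number 5 percentage points higher from compound 2 to compound 3 (within the scatter) both exchange the group on the triple-bonded carbon, and a number 2 percentage points higher from compound 1 to compound 2 (within the scatter) alters that group only slightly; all three stay within the scatter. Compound 4 `CNC(=O)[C@@]12C[C@@H]1[C@@H](n1cnc3c(NC)nc(C#Cc4cccnn4)nc31)[C@H](O)[C@@H]2O` differs from compound 3 by pyridazin-3-yl in place of pyrimidin-2-yl on a triple-bonded carbon. The two earlier exchanges at this position bear on it, and since both left the numbers within the scatter, no step beyond the scatter is expected in this assay no change at the digits printed from compound 3 to compound 4 (within the scatter). Compound 4 is therefore estimated to give 25%, between 15% and 35%.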

Compound 4, a percentage reported as inhibition, at one concentration (the size of the read-out at that concentration, not a potency): 11%
Compound 4: the middle estimate sits 14 percentage points above what was measured; the measured number lies below the stated range.
By their numbers in this assay, from the lowest: compounds 4, 1, 2 and 3 (each within the scatter of the next, the first and the last beyond it).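

In this assay, the position on the triple-bonded carbon distinguishes two groups with the same atoms, joined differently: a number 14 percentage points lower from compound 3 to compound 4 (beyond the scatter), the only step shown that goes beyond the scatter. The pyridazin-3-yl group is not set apart from the phenyl groups, with a number 9 percentage points lower from compound 2 to compound 4 (within the scatter) and a number 7 percentage points lower from compound 1 to compound 4 (within the scatter), so the separation holds only against pyrimidin-2-yl. Nothing available explains this step. Left open is how a pyridin-2-yl group, or an amine carried on the pyridazin-3-yl ring, would read at this position.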